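The source may report more compounds than this note shows. Statements on the series, on what has been measured and on what is new or still open speak of the compounds shown alone.

- Compound 1 `Nc1ccccc1NC(=O)/C=C/c1ccc(CSc2ccc(C(F)(F)F)cn2)cc1`: 20.1%
- Compound 2 `Cc1ccc(SCc2ccc(/C=C/C(=O)Nc3ccccc3N)cc2)cc1`: 22.2%

In a functional assay on SMMC-7721 cells (Homo sapiens) for inhibition, read by CCK-8 assay, with a stated time of 72 h, tested at 8 uM (a higher number here means more inhibition of growth at the concentration tested, a lower number less inhibition of growth), compound 2 gives 22.2% and compound 1 gives 20.1%, so the two stand level within the scatter. Compound 3 `Nc1ccccc1NC(=O)/C=C/c1ccc(CSc2ccc(F)cc2)cc1` differs from compound 2 in one place: fluoro in place of methyl on an aromatic carbon, para to a large group. Within the data shown here, the only measured step, a number 2.1 percentage points higher from compound 1 to compound 2 (within the scatter), exchanged a larger group on the sulfur and stayed within the scatter. It is thin evidence, but no step beyond the scatter is expected in this assay. The expected change is a number 0.2 percentage points lower from compound 2 to compound 3 (within the scatter). For compound 3 the estimated value is 22%, within an expected range of 12% to 35%.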

Compound 3, percent growth inhibition at one concentration: 15.4%
Compound 3: middle estimate off by 6.6 percentage points, on the high side, and the stated range covers the measured number.
By their numbers in this assay, from the lowest: compounds 3, 1 and 2 (each within the scatter of the next).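

At this place, on an aromatic carbon para to a large group, fluoro in place of methyl gives a number 6.8 percentage points lower from compound 2 to compound 3 (within the scatter) in this assay. Replacing 5-(trifluoromethyl)pyridin-2-yl on the sulfur with 4-fluorophenyl gives a number 4.7 percentage points lower from compound 1 to compound 3 (within the scatter), so all three groups on the sulfur now stand level in this assay. No measurement shown offers an explanation for these small differences.

As far as these compounds go, it remains open whether an amine or a carboxylic acid at this same place would move the number beyond the scatter.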